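The compounds below may be only part of what the source reports. "The series", "measured", "known", "first", "only" and "open" are said of these compounds alone.

Working notes on the series

Two cores are followed here. Compound 1 `Cn1c(-c2ccc([N+](=O)[O-])cc2)nc2cc(C(F)(F)F)ccc21` carries a nitro group, and compound 2 `Cn1c(-c2ccc(N)cc2)nc2cc(C(F)(F)F)ccc21` is its amino counterpart; the change between them is amino in place of nitro on an aromatic carbon. Compound 3 `COc1ccc(-c2nc3cc(Cl)c(Cl)cc3[nH]2)c([N+](=O)[O-])c1` sits on a second core, and the difference between the two cores is not broken down here. Compound 4 `COc1ccc(-c2nc3cc(Cl)c(Cl)cc3[nH]2)c(N)c1` is the amino counterpart of compound 3 and has not yet been measured.

In an ADME assay on BHK cells (Mesocricetus auratus) for cytotoxicity, read by MTT assay, with a stated time of 96 h (on this read-out lower numbers stand for higher toxicity in this test and higher numbers for lower toxicity in this test), compound 1 reaches only the limit of the assay and gives > 100000 nM. In this assay compound 2 gives 85000 nM. The measured step is an at least 1.1-fold lower number from compound 1 to compound 2 (0.07 log units; that floor lies within the scatter), and its floor rests on (the limit of > 100000 nM in this assay, at which 1 of the 3 values shown sits). In this assay compound 3 gives 80000 nM; its value and that of compound 2 sit within the scatter of each other, so no order is read between them.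

The change from compound 3 to compound 4 is amino in place of nitro on an aromatic carbon. It is the same kind of change as that from compound 1 to compound 2, but the place differs: in compound 1 the group is para to a large group, whereas in compound 3 it is ortho to a large group and meta to a methoxy group.

The earlier step lies within the scatter, so the expected step of a 1.1-fold lower number from compound 3 to compound 4 (0.06 log units; within the scatter) is set small. Compound 3 at 80000 nM serves as the anchor for this expectation. Compound 4 is therefore estimated at 70000 nM in this assay, with an expected range from 25000 nM to 150000 nM.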

Compound 4, half-maximal cytotoxic concentration: > 100000 nM
Compound 4: no number, only a limit (the forecaster's own chance of this, stated with the estimate: 30%); middle value at least 1.4-fold (0.15 log units) from the limit.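

In this assay compound 4 gives > 100000 nM, which is a limit of the assay and not a number. Set beside the earlier case, an at least 1.2-fold higher number from compound 3 to compound 4 (0.09 log units; that floor lies within the scatter) can be compared with the first step only as far as two floors allow: the same change on two cores in this assay, an at least 1.1-fold lower number (0.07 log units; that floor lies within the scatter) from compound 1 to compound 2 and an at least 1.2-fold higher number (0.09 log units; that floor lies within the scatter) from compound 3 to compound 4; the limit leaves it open whether they differ The result shows that neither floor lies beyond the scatter, but it does not show that the change carries over from one core to the other, nor that it fails to, since the comparison rests on values at the limit: the limit of > 100000 nM in this assay, at which 2 of the 4 values shown sit.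

Open, from the compounds shown here alone, is how other groups on the same aromatic carbon, such as an amide, a hydroxyl or a carboxylic acid, would read on either core in this assay. Also open is whether the place of the group matters apart from the core, as no pair shown keeps one core and moves the nitro or amino group to another place on the ring.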